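The source may report more compounds than this note shows. Statements on the series, on what has been measured and on what is new or still open speak of the compounds shown alone.

Compound 3 `C#CCN(C)Cc1cc2cc(O)ccc2n1C` sits at the low end of the three numbers seen so far in an assay on isolated protein for inhibition of Amine oxidase [flavin-containing] A (Rattus norvegicus) (a higher number here means a weaker inhibitor, a lower number a stronger inhibitor), giving 4 nM. Compound 1 `CC#CCN(C)Cc1cc2cc(O)ccc2n1C` gives 5.7 nM in this assay, and the step of a 1.4-fold lower number from compound 1 to compound 3 (0.15 log units; within the scatter) stays within the scatter. Compound 2 `C#CCNCc1cc2ccccc2n1C`, which carries neither the hydroxyl nor the methyl on the amine nitrogen, gives 240 nM in this assay. Compound 4 `C#CCNCc1cc2cc(O)ccc2n1C` differs from compound 3 by a single change, (hydrogen in place of methyl on an amine nitrogen). Among the compounds with values here, no measured step isolates that change; the gap between compound 2 and compound 3 spans two changes at once, so its size cannot be assigned to the amine methyl alone. A moderate rise in this assay is expected, a 5.0-fold higher number from compound 3 to compound 4 (0.70 log units; beyond the scatter). Compound 4 is therefore estimated at 20 nM, with a range from 5 nM to 100 nM.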

Compound 4, inhibition constant: 4000 nM
Estimate against measurement, compound 4: 200-fold (2.30 log units) below, and the stated range ends below it.
By their numbers in this assay, from the lowest: compounds 3 and 1 (each within the scatter of the next); then compound 2; then compound 4.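

In this assay, within the data shown here, the methyl on the amine nitrogen carries far more weight than the earlier compounds could show: a 1000-fold higher number from compound 3 to compound 4 (3.00 log units; beyond the scatter), and a 700-fold higher number from compound 1 to compound 4 (2.85 log units; beyond the scatter), a step that also replaces but-2-yn-1-yl with propargyl. With hydrogen on that nitrogen, the hydroxy on the aromatic carbon goes with a rise as well, a 17-fold higher number from compound 2 to compound 4 (1.22 log units; beyond the scatter). No evidence is available to explain these steps. On these data alone, whether the hydroxy acts the same way when the amine nitrogen carries methyl remains open. So does whether an ethyl group on that nitrogen, or a methoxy group in place of the hydroxy, would keep the number low.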